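The source may report more compounds than this note shows. Statements on the series, on what has been measured and on what is new or still open speak of the compounds shown alone.

Measured so far:
- compound 1, `O=c1oc2ccccc2c2nc3c(ccc4cc[nH]c43)c(-c3cccnc3Cl)c12`: 70700 nM
- compound 2, `O=c1cc(O)c2cc(Cl)ccc2o1`: 70700 nM
- compound 3, `O=c1oc2ccccc2c2nc3c(ccc4cc[nH]c43)c(-c3ccc(Cl)cc3)c12`: 70700 nM

In a functional assay on B16-F10 cells (Mus musculus) for cytotoxicity (a lower number here means a stronger inhibitor, a higher number a weaker inhibitor), compound 1 gives 70700 nM, and on these numbers it stands level with compound 2 and compound 3; none of the three is set apart from the others by more than the usual scatter of repeated measurements.

Compound 4, `O=c1oc2ccccc2c2nc3c(ccc4cc[nH]c43)c(-c3cccc(Cl)c3Cl)c12`, has not yet been measured in this assay. It differs from compound 1 in one place: 2,3-dichlorophenyl in place of 2-chloropyridin-3-yl on an aromatic carbon.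

One measured step speaks to this kind of change, the exchange of the same group on the same aromatic carbon of the shared core: no change at the digits printed from compound 1 to compound 3 (within the scatter). That exchange left the read-out where it was. Among the compounds with values here, compound 2 carries a different core and offers no step toward compound 4, so only the step from compound 1 to compound 3 serves as a guide. On that guide, no step beyond the scatter is expected for compound 4, in either direction: no change at the digits printed from compound 1 to compound 4 (within the scatter). Compound 4 is therefore expected to give about 70700 nM in this assay, within a range from 35000 nM to 141000 nM.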

Compound 4, half-maximal inhibitory concentration: 70700 nM
Estimate against measurement, compound 4: no gap at the digits printed; low and high end bracket the measured number.
By their numbers in this assay, from the lowest: compounds 1, 2, 3 and 4 (each within the scatter of the next).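

In this assay, 2,3-dichlorophenyl in place of 2-chloropyridin-3-yl gives no change at the digits printed from compound 1 to compound 4 (within the scatter), and 2,3-dichlorophenyl in place of 4-chlorophenyl gives no change at the digits printed from compound 3 to compound 4 (within the scatter). Within the data shown here, the earlier step compared only two groups on this aromatic carbon, whereas three now read alike: one ring with a nitrogen and one chlorine, one of carbon only with one chlorine, and one of carbon only with two chlorines. No measured evidence bears on why these exchanges leave the read-out in place.

Every group shown on this carbon is a six-membered aromatic ring carrying chlorine, so it remains open whether a plain phenyl, a methoxyphenyl or a ring with fluorine would read the same. An amine, a carboxylic acid or a longer chain on this carbon also remains an open case.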